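This account rests on a few compounds, and the source may have more. Where it says the series, first, only, none or still open, it means among the compounds named here.

Compound 1 `Fc1nc(C#Cc2ccccc2)cs1` is the starting point. In an assay on brain for displacement of a labelled ligand from metabotropic glutamate receptor 5 (Rattus norvegicus) (on this read-out lower numbers stand for stronger inhibition and higher numbers for weaker inhibition), compound 1 gives 122 nM, the highest of the three measured numbers: compound 2 `N#Cc1cccc(C#Cc2csc(I)n2)c1` gives 4.2 nM and compound 3 `N#Cc1cccc(C#Cc2csc(N)n2)c1` gives 0.9 nM. Compound 4 `COc1cccc(C#Cc2csc(F)n2)c1` differs from compound 1 by methoxy in place of hydrogen on an aromatic carbon. Among the compounds with values here, no measured step touches this place. Within the data shown here, the one step on record, a 4.7-fold lower number from compound 2 to compound 3 (0.67 log units; beyond the scatter), alters the group on the shared core, and compounds 2 and 3 each differ from compound 1 in two places at once, so their much lower numbers cannot be tied to either change alone. A modest move toward a lower number in this assay is therefore expected for compound 4, a 3.1-fold lower number from compound 1 to compound 4 (0.48 log units; beyond the scatter). Compound 4 is estimated at 40 nM, within a range from 10 nM to 160 nM.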

Compound 4, inhibition constant: 22.7 nM
The estimate for compound 4 lay 1.8-fold (0.25 log units) above the measured number; the range from low to high includes it.
By their numbers in this assay, from the lowest: compound 3; then compound 2; then compound 4; then compound 1.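

In this assay, within the data shown here, methoxy in place of hydrogen on the six-membered aromatic ring of carbon only gives a 5.4-fold lower number from compound 1 to compound 4 (0.73 log units; beyond the scatter) and so provides the first reading of a single change at this place. The earlier compounds shown here could not show this, as compounds 2 and 3 each differ from compound 1 in two places at once. No measurement shown gives a reason for this shift. As far as these compounds go, whether ethoxy, hydroxy or a chlorine atom at the same place would move the number as far stays open.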